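Porcupine series: six-membered aryl in place of the furan

The source may report more compounds than this note shows. Statements on the series, on what has been measured and on what is new or still open speak of the compounds shown alone.

Measured compounds, in an assay on L cells for inhibition of Protein-serine O-palmitoleoyltransferase porcupine (Mus musculus), read by reporter gene assay, with a stated time of 24 h; a lower number here means that less compound is needed, a higher number that more compound is needed for the effect:
compound 1 `O=C(CSc1nc2c(c(=O)n1-c1ccccc1)SCC2)Nc1ccc(-c2cccs2)cn1` gives 0.3 nM
compound 2 `O=C(CSc1nc2c(c(=O)n1-c1ccccc1)SCC2)Nc1ccc(-c2ccoc2)cn1` gives 1.5 nM
compound 3 `COc1ccc2nc(NC(=O)CNC(=O)c3ccc(=O)n(-c4ccccc4)c3)sc2c1` gives > 25000 nM, a limit of the assay rather than a number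

Compound 2 stands at the highest of the two numbers in this assay; its nearest neighbour is compound 1, and the step of a 5.0-fold higher number from compound 1 to compound 2 (0.70 log units; beyond the scatter) is beyond the scatter. Compound 3, on a different core, sits at the limit of > 25000 nM in this assay, at which 1 of the 3 values shown sits, which only shows that it is far weaker than the other two.

Compound 4 `O=C(CSc1nc2c(c(=O)n1-c1ccccc1)SCC2)Nc1ccc(-c2cccnc2)cn1` is the next change on the core shared with compound 2: pyridin-3-yl in place of furan-3-yl on an aromatic carbon. Among the compounds with values here, the only measured step on this carbon, a 5.0-fold higher number from compound 1 to compound 2 (0.70 log units; beyond the scatter), exchanged one five-membered ring for another and moved the number modestly. No measured step exchanges a five-membered ring for a six-membered one, so the effect of the pyridin-3-yl itself is not anchored by any shown pair.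

Compound 4 is therefore expected to land near compound 2, with a step of about a 1.5-fold lower number from compound 2 to compound 4 (0.18 log units; within the scatter) that may well lie within the scatter. The estimate for compound 4 in this assay is 1 nM, with a range from 0.3 nM to 4 nM.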

Compound 4, half-maximal effective concentration: 1 nM
Beside the measured number, compound 4's estimate shows no gap at the digits printed; the measured number falls inside the stated range.
By their numbers in this assay, from the lowest: compound 1; then compounds 4 and 2 (each within the scatter of the next). At a limit, above all of these: compound 3.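

In this assay, within the data shown here, the carbon para to a large group accepts a six-membered aromatic ring, which no earlier pair showed: a 1.5-fold lower number from compound 2 to compound 4 (0.18 log units; within the scatter), so pyridin-3-yl and furan-3-yl cannot be told apart here. Against thiophen-2-yl the same ring gives a step that is beyond the scatter: a 3.3-fold higher number from compound 1 to compound 4 (0.52 log units; beyond the scatter), and with a 5.0-fold higher number from compound 1 to compound 2 (0.70 log units; beyond the scatter) this leaves compound 1 with the lowest number on the shared core, so ring size alone does not sort these groups, since the two five-membered rings differ from each other beyond the scatter while furan-3-yl and pyridin-3-yl do not. No measurement shown gives a reason for any of these steps.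

Open, on these data alone, is whether the ring nitrogen of pyridin-3-yl matters at all, which a plain phenyl, pyridin-2-yl or pyridin-4-yl on this carbon would test against compound 4. Also open, as far as these compounds go, is how far the position extends beyond aromatic rings, for example to a saturated amine such as morpholin-4-yl or to a carboxylic acid.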